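From Dimethoxyphenyl to Bromophenyl on a Weak Compound

A few compounds are considered here, and "the series" means these few. Any claim that something is new, unique, unknown or untested is made for them only; others in the source may bear on it.

In a functional assay on MDA-MB-231 cells (Homo sapiens) for cytotoxicity, read by MTT assay, with a stated time of 72 h (a lower number here means a stronger inhibitor, a higher number a weaker inhibitor), compound 1 `COc1ccc(NC(=O)CN2CCN(c3nnc(Cc4ccncc4)c4ccccc34)CC2)cc1OC` gives 100 nM while compound 2 `COc1ccc(NC(=O)CN2CCN(c3nnc(Cc4ccccc4)c4ccccc34)CC2)cc1OC` gives 32200 nM as the higher of the two numbers, which makes compound 2 the weaker inhibitor. Placing phenyl where pyridin-4-yl stood, on a saturated chain carbon bound to an aromatic carbon, produced a 320-fold higher number from compound 1 to compound 2 (2.51 log units; beyond the scatter) as the only measured step.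

Compound 3 `O=C(CN1CCN(c2nnc(Cc3ccccc3)c3ccccc23)CC1)Nc1cccc(Br)c1` keeps that phenyl and differs from compound 2 at another place, with 3-bromophenyl in place of 3,4-dimethoxyphenyl on an amide-type nitrogen as the whole change. Among the compounds with values here, no measurement yet covers an exchange at this nitrogen. Within the data shown here, the one measured step shows only that a single exchange on the shared core can move the number far, and it sets no direction here. Since compound 2 already stands at 32200 nM a moderate move toward a lower number is expected, though a result within the scatter remains possible. The expected change is a 2.7-fold lower number from compound 2 to compound 3 (0.43 log units; beyond the scatter) in size. Compound 3 is estimated at 12000 nM with an expected range from 1500 nM to 50000 nM.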

Compound 3, half-maximal inhibitory concentration: 3880 nM
Estimate against measurement, compound 3: 3.1-fold (0.49 log units) above, within the range that was stated.
By their numbers in this assay, from the lowest: compound 1; then compound 3; then compound 2.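

Within the data shown here, this is the first exchange on the amide-type nitrogen that can be read, and in this assay putting 3-bromophenyl in place of 3,4-dimethoxyphenyl gives an 8.3-fold lower number from compound 2 to compound 3 (0.92 log units; beyond the scatter) on a compound that keeps its phenyl. So the number responds to this position as well as to the place changed earlier, although this step is smaller than a 320-fold higher number from compound 1 to compound 2 (2.51 log units; beyond the scatter) at that other place. The two groups differ in several ways at once: bromine enters, both oxygen atoms leave, and the counts of heavy atoms and hydrogen-bond acceptors fall, so this single step cannot show which of these differences goes with the lower number.

No measured evidence is available to explain the size or direction of this step. On these data alone, it remains open whether 3-bromophenyl would move the number in the same way on compound 1, which carries pyridin-4-yl, and what an unsubstituted phenyl, a 3-chlorophenyl or a phenyl bearing a carboxylic acid would do on the same nitrogen.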